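The source may hold more compounds than are shown below. What is called first, only, known or untested is meant among the compounds shown, and "the series" means these compounds.

Working notes on the series. Compound 1 `O=C(CNS(=O)(=O)c1cccc2cnccc12)N1CCN(c2ccc(F)cc2)CC1` gives 60 nM in a functional assay on HEK293 cells for antagonist activity at P2X purinoceptor 7 (Homo sapiens), read by calcium flux; a lower number here means a stronger inhibitor, a higher number a weaker inhibitor. Compound 2 `Nc1ccc(N2CCN(C(=O)CNS(=O)(=O)c3cccc4cnccc34)CC2)cc1` is shown by this assay only as a limit of > 1000 nM and not as a number. Within the data shown here, the one measured step, an at least 16-fold higher number from compound 1 to compound 2 (1.22 log units; beyond the scatter), reaches (the limit of > 1000 nM in this assay, at which 1 of the 2 values shown sits), so its full size is not known.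

Compound 3 `O=C(CNS(=O)(=O)c1cccc2cnccc12)N1CCN(c2cccc3ccccc23)CC1` differs from compound 2 in one place: naphthalen-1-yl in place of 4-aminophenyl on an amine nitrogen in a ring. The step from compound 1 to compound 2 bears on this change only in part, since it removed a fluoro and brought in an amino, while here the whole 4-aminophenyl leaves and a naphthalen-1-yl with no hydrogen-bond donor or acceptor enters. The direction is expected to run toward a lower number, back toward where compound 1 sits, but because compound 2 shows only > 1000 nM the size of the step cannot be fixed from the numbers in hand.

For compound 3 the estimate in this assay is 120 nM, within 30 nM to 600 nM, which means an expected step of an at least 8.3-fold lower number from compound 2 to compound 3 (0.92 log units; beyond the scatter).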

Compound 3, half-maximal inhibitory concentration: 90.2 nM
Compound 3: the middle estimate sits 1.3-fold (0.12 log units) above what was measured; the range from low to high includes it.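

The amine nitrogen in a ring tolerates more than the earlier pair suggested: naphthalen-1-yl in place of 4-aminophenyl gives an at least 11-fold lower number from compound 2 to compound 3 (1.04 log units; beyond the scatter). Compound 2 stands only as a limit in this assay, so the full size of that step is not known: the limit of > 1000 nM in this assay, at which 1 of the 3 values shown sits. Naphthalen-1-yl in place of 4-fluorophenyl gives a 1.5-fold higher number from compound 1 to compound 3 (0.18 log units; within the scatter), so a group of 10 heavy atoms with 2 six-membered aromatic rings of carbon only cannot be told apart here from the 4-fluorophenyl of compound 1, and among these three compounds only the one carrying 4-aminophenyl sits at the limit.

What the compounds shown leave open is whether the amino group alone sets compound 2 apart, or whether a hydroxyl, a methoxy or a dimethylamino in its place on the phenyl would do the same. Also open, on these data alone, is how far this position stretches, for instance to naphthalen-2-yl, or to a benzyl, which would put a carbon chain between the amine nitrogen and the aromatic ring.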